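Thiourea-type replacement on a shortened chain in the series

The source may report more compounds than this note shows. Statements on the series, on what has been measured and on what is new or still open speak of the compounds shown alone.

Three compounds share one core and differ only in the chain and its terminal group. Compound 1 `C/N=C(/NC#N)NCCCCCCn1nc(-c2ccccc2)ccc1=O` gives 31.7% in a functional assay on the whole organism with Rattus norvegicus as the target, at a dose of 100 mg/kg; on this read-out higher numbers stand for more inhibition at the one dose given (going by the name of the read-out) and lower numbers for less inhibition. Compound 2 `C/N=C(/NC#N)NCCCCCn1nc(-c2ccccc2)ccc1=O` gives 47.6% in this assay, the highest of the three numbers: the step from compound 1 is a number 15.9 percentage points higher from compound 1 to compound 2 (beyond the scatter), and compound 3 `CCC/N=C(/NC#N)NCCCCCn1nc(-c2ccccc2)ccc1=O` gives 27.5%, a step of a number 20.1 percentage points lower from compound 2 to compound 3 (beyond the scatter). The step of a number 4.2 percentage points lower from compound 1 to compound 3 (within the scatter) lies within the scatter.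

Compound 4 `C=CCNC(=S)NCCCCn1nc(-c2ccccc2)ccc1=O` is not yet measured. The change from compound 2 is a group of 7 heavy atoms (4 carbon, 2 nitrogen, 1 sulfur; no ring) in place of a group of 8 heavy atoms (4 carbon, 4 nitrogen; no ring), on a saturated chain carbon, four bonds along the chain from an aromatic nitrogen. Both measured steps beyond the scatter sat on a saturated chain carbon five bonds along the chain from an aromatic nitrogen, while this change sits four bonds along; neither measured step exchanges nitrogen for sulfur or removes the triple bond, so neither bears on it directly. The steps of a number 15.9 percentage points higher from compound 1 to compound 2 (beyond the scatter) and a number 20.1 percentage points lower from compound 2 to compound 3 (beyond the scatter) show that changes of this size at the chain end move the read-out by modest amounts in either direction, which sets the expected range wide. Compound 4 is expected to give 30%, between 10% and 55% in this assay. That estimate means an expected step of a number 17.6 percentage points lower from compound 2 to compound 4 (beyond the scatter).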

Compound 4, a percentage reported as inhibition, in the whole organism at one dose (the size of the read-out at that dose, not a potency): 27.1%
Compound 4: the middle estimate sits 2.9 percentage points above what was measured; the measured number falls inside the stated range.
By their numbers in this assay, from the lowest: compounds 4, 3 and 1 (each within the scatter of the next); then compound 2.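

Among the compounds shown here, this is the first reading at the place four bonds along the chain from an aromatic nitrogen, and the first for an end group that carries sulfur and no triple bond. In this assay, this change gives a number 20.5 percentage points lower from compound 2 to compound 4 (beyond the scatter), so compound 2 remains the highest of the series, and a sulfur-bearing end group at this place does not keep its number. The step is a single change of both chain attachment and end group, so it gives one combined size rather than a separate contribution from each, and no measurement of any property of these groups is available to account for it.

The compounds shown leave open how the step divides between the chain and the end group, since the end group of compound 2 is seen only at five bonds along and the sulfur-bearing end group of compound 4 only at four bonds along. Also open, from the compounds shown here alone, is how the read-out responds to a urea with oxygen in place of the sulfur, or to a simple amine at the chain end.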